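One Methyl Added to a Dihydroxyphenyl Group

The compounds below may be only part of what the source reports. "The series", "measured", "known", "first", "only" and "open" are said of these compounds alone.

Measured compounds:
compound 1 `CN(C)CCn1cnnc1-c1cc(Oc2ccc(NC(=O)N/N=C/c3ccc(F)cc3)cc2F)ccn1` gives 1030 nM
compound 2 `COc1cc(/C=N/NC(=O)Nc2ccc(Oc3ccnc(-c4nncn4CCN(C)C)c3)c(F)c2)cc(OC)c1OC` gives 2900 nM
compound 3 `CN(C)CCn1cnnc1-c1cc(Oc2ccc(NC(=O)N/N=C/c3ccc(O)c(O)c3)cc2F)ccn1` gives 3240 nM

All three numbers come from a functional assay on MKN-45 cells (Homo sapiens) for cytotoxicity, read by MTT assay, with a stated time of 72 h; on this read-out higher numbers stand for weaker inhibition and lower numbers for stronger inhibition. Compound 3 stands at the highest number of the three, but compound 2 lies within the scatter of it: a 1.1-fold higher number from compound 2 to compound 3 (0.05 log units; within the scatter). Only compound 1 is clearly apart, as a 3.1-fold higher number from compound 1 to compound 3 (0.50 log units; beyond the scatter) shows, and the change from compound 1 to compound 2 was of similar size: a 2.8-fold higher number from compound 1 to compound 2 (0.45 log units; beyond the scatter).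

Compound 4 `COc1ccc(/C=N/NC(=O)Nc2ccc(Oc3ccnc(-c4nncn4CCN(C)C)c3)c(F)c2)cc1O` differs from compound 3 in one place: methyl in place of hydrogen on an oxygen on an aromatic ring. Among the measured compounds shown here, the step that bears most on this is the one from compound 2 to compound 3, where a 3,4,5-trimethoxyphenyl and a 3,4-dihydroxyphenyl gave numbers within the scatter of each other. Compound 4, with one hydroxy turned into methoxy, sits between those two patterns, so no step beyond the scatter is expected in this assay, that is a 1.2-fold lower number from compound 3 to compound 4 (0.06 log units; within the scatter). Compound 4 is therefore estimated at 2800 nM, in a range from 1400 nM to 5600 nM.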

Compound 4, half-maximal inhibitory concentration: 2510 nM
For compound 4 the middle estimate is 1.1-fold (0.05 log units) above the measured one, and the stated range covers the measured number.
By their numbers in this assay, from the lowest: compound 1; then compounds 4, 2 and 3 (each within the scatter of the next).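

In this assay, a methyl on one oxygen of the 3,4-dihydroxyphenyl group gives no step beyond the scatter (a 1.3-fold lower number from compound 3 to compound 4 (0.11 log units; within the scatter)), so at this position hydroxy and methoxy cannot be told apart. The 3-hydroxy-4-methoxyphenyl group also stays within the scatter of the 3,4,5-trimethoxyphenyl group (a 1.2-fold lower number from compound 2 to compound 4 (0.06 log units; within the scatter)) but remains clearly apart from the 4-fluorophenyl group (a 2.4-fold higher number from compound 1 to compound 4 (0.39 log units; beyond the scatter)), so the three oxygen-bearing rings read alike and only compound 1 stands clear of them. Nothing measured here explains this pattern.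

The compounds shown leave open whether an ethyl group or a longer chain ending in an amine on that oxygen would also stay within the scatter. They also leave open whether the gap to compound 1 depends on its fluorine, which a chloro group or plain phenyl could test.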